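This account rests on a few compounds, and the source may have more. Where it says the series, first, only, none or still open, it means among the compounds named here.

Measured set in hand:
- compound 1 `C=C1CC[C@H]2C(C)(C)CCC[C@]2(C)[C@H]1C/C=C1/C(=O)OC[C@H]1O` — 10.8%
- compound 2 `C=C1CC[C@H]2C(C)(C)CCC[C@]2(C)[C@H]1/C=C/C1=CCOC1=O` — 170%
- compound 3 `C=C1CC[C@H]2C(C)(C)CCC[C@]2(C)[C@H]1CC=O` — 72.8%

In a functional assay on RAW264.7 cells (Mus musculus) for inhibition, read by ELISA, with stated times of 1 h and 18 h, tested at 20 uM (on this read-out lower numbers stand for a stronger effect and higher numbers for a weaker effect at the one concentration tested), compound 1 gives 10.8%, the lowest of the three numbers and thus the strongest effect in the set. Compound 3 gives 72.8%, a number beyond the scatter from compound 1. Compound 2 gives 170%, the furthest from compound 1 and again beyond the scatter. Within the data shown here, no two of the measured compounds differ in only one place, so no single step between measured compounds is available to calibrate what a small change does in this assay.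

Compound 4 `C=C1CC[C@H]2C(C)(C)CCC[C@]2(C)[C@H]1C/C=C1\C(=O)OC[C@H]1O` is still to be measured. Its relation to compound 1 is the two compounds have the same atoms and bonds and differ only in configuration as drawn: 1 of 5 stereo elements differ; a double bond is drawn E in compound 1 and Z in compound 4. With no measured step of this kind in the set, the size of the step in this assay is uncertain; a moderate shift toward a higher number, that is a weaker effect, beyond the scatter is expected, but a step within the scatter cannot be ruled out. The expected step is a number 24.2 percentage points higher from compound 1 to compound 4 (beyond the scatter). For compound 4 the estimate in this assay is 35%, within 8% to 85%.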

Compound 4, a percentage reported as activity, at one concentration (the size of the read-out at that concentration, not a potency): 10.1%
For compound 4 the middle estimate is 24.9 percentage points above the measured one; the range from low to high includes it.
By their numbers in this assay, from the lowest: compounds 4 and 1 (each within the scatter of the next); then compound 3; then compound 2.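

In this assay, among these compounds, the double bond geometry is the first single change that can be read, and the step is a number 0.7 percentage points lower from compound 1 to compound 4 (within the scatter). At this double bond, the E and Z drawings therefore cannot be told apart at the one concentration tested, so this read-out gives no preference for either geometry. The comparison isolates configuration alone, with no group entering or leaving: the fact that compounds 1 and 4 differ only in the configuration as drawn.

A single-concentration read-out leaves open whether the two geometries would also match across a range of concentrations. The compounds shown also leave open what an amine or a carboxylic acid in place of the hydroxyl would do in this assay, and whether the geometry would still make so little difference with such a group present.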